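The source may report more compounds than this note shows. Statements on the series, on what has been measured and on what is new or still open speak of the compounds shown alone.

Measured so far:
Compound 1, `CC1CC/C(=N\Nc2ccccc2)c2ncc(CC(=O)O)c(=O)n21`: in a functional assay on the whole organism for inhibition, with Rattus norvegicus as the target (on this read-out lower numbers stand for an effect already at smaller amounts and higher numbers for an effect only at larger amounts of compound), compound 1 gives 100 umol/kg.
Compound 2, `CC1CC/C(=N\Nc2ccccc2F)c2ncc(C(=O)O)c(=O)n21`: in this assay compound 2 gives 5 umol/kg.

Compound 2 stands lowest of the two numbers, which on this read-out means it produces the effect at the smaller amount. Among the measured compounds shown here, compound 1 is the only neighbour, and its number is higher by a margin that lies beyond the usual scatter of repeated measurements. Compound 1 and compound 2 differ in more than one place, so nothing can be said about which of those places carries the difference between their values.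

Compound 3, `CC1CC/C(=N\Nc2ccc(O)cc2)c2ncc(C(=O)O)c(=O)n21`, keeps the core and the acid of compound 2 and changes one group: 4-hydroxyphenyl in place of 2-fluorophenyl on an amine nitrogen. No pair of measured compounds shares this change, so the size and direction of its effect are unknown from the data shown. A modest step is expected rather than a large one, because compound 2 gives 5 umol/kg and the rest of compound 3 matches compound 2. Compound 3 is estimated at 10 umol/kg, within a range from 3 umol/kg to 40 umol/kg, which would mean an expected step of a 2.0-fold higher number from compound 2 to compound 3 (0.30 log units; within the scatter).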

Compound 3, dose for 50% inhibition: 1.7 umol/kg
For compound 3 the middle estimate is 5.9-fold (0.77 log units) above the measured one; measured number below the stated range.
By their numbers in this assay, from the lowest: compound 3; then compound 2; then compound 1.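

Placing 4-hydroxyphenyl instead of 2-fluorophenyl on the amine nitrogen gives a 2.9-fold lower number from compound 2 to compound 3 (0.47 log units; beyond the scatter) in this assay, so this group can be changed without losing the effect, and here the change lowers the amount needed. Unlike the comparison of compound 1 with compound 2, this pair differs in one place only, so the step can be assigned to that single change on the shared core and acid. Both groups have a six-membered aromatic ring of carbon and the same number of heavy atoms, yet fluorine leaves and oxygen enters, bringing a hydrogen-bond donor and acceptor, and nothing measured here accounts for the step.

The single swap changes both the atom on the ring and the place named for it, so the compounds shown cannot tell whether the step belongs to losing the fluorine, gaining the hydroxyl, or the change from a 2-substituted to a 4-substituted ring. Groups such as 4-fluorophenyl, 2-hydroxyphenyl or 4-methoxyphenyl on the same core and acid would separate these possibilities.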